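A few compounds are considered here, and "the series" means these few. Any claim that something is new, unique, unknown or untested is made for them only; others in the source may bear on it.

Compound 1 `O=C(Nc1cccc(OC(=O)c2ccc(CO[N+](=O)[O-])cc2)c1)c1ccc(CO[N+](=O)[O-])cc1`: 7600 nM
Compound 2 `O=C(Nc1ccccc1)c1ccc(CCl)cc1`: 800 nM

In a functional assay on SW-620 cells (Homo sapiens) for antiproliferative activity, read by CCK-8 assay and cell counting, with a stated time of 72 h (on this read-out higher numbers stand for weaker inhibition and lower numbers for stronger inhibition), compound 2 stands lowest of the two at 800 nM, and its gap to compound 1 lies beyond the usual scatter. Compound 3 `O=C(Nc1ccccc1)c1ccc(CO[N+](=O)[O-])cc1` has not yet been measured. It departs from compound 2 by a single change, nitrooxy in place of chloro on a saturated chain carbon bound to an aromatic carbon. Going by the values given here, no measured pair isolates this change. Among the compounds with values here, the only guide is compound 1, which carries nitrooxy groups and gives 7600 nM, and on that ground a step to a higher number, beyond the scatter, is expected in this assay. That guide is loose, as compound 1 also differs from compound 2 in other places. The expected step is a 3.1-fold higher number from compound 2 to compound 3 (0.49 log units; beyond the scatter). For compound 3 the estimated value is 2500 nM, with an expected range from 700 nM to 9000 nM.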

Compound 3, half-maximal inhibitory concentration: 800 nM
Estimate against measurement, compound 3: 3.1-fold (0.49 log units) above; measured number inside the range.
By their numbers in this assay, from the lowest: compounds 2 and 3 (each within the scatter of the next); then compound 1.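

In this assay, nitrooxy in place of chloro on a saturated chain carbon bound to an aromatic carbon gives no change at the digits printed from compound 2 to compound 3 (within the scatter), so at this position the two groups cannot be told apart by this read-out. Compound 1 could give only a loose hint about nitrooxy, whereas this pair isolates the exchange in a single place and shows that the larger group, with its added hydrogen-bond acceptors, leaves the number unmoved. Nothing available explains why the two groups read alike.

Going by these compounds, whether this tolerance extends to other groups at the same carbon, such as an amine, a carboxylic acid or a longer chain, remains open. The compounds shown also cannot apportion the value of compound 1 7600 nM among its several differences from the shared core.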